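The compounds below may be only part of what the source reports. "The series", "measured", "known", "first", "only" and "open" are said of these compounds alone.

Measured so far:
compound 1, `O=C1NCCc2nc(C#Cc3cccc(F)c3)sc21`: > 10000 nM in an assay on HEK293 cells for negative allosteric modulation of metabotropic glutamate receptor 5 (Homo sapiens), read by FLIPR, with a stated time of 1 h (on this read-out higher numbers stand for weaker inhibition and lower numbers for stronger inhibition), which is a limit of the assay rather than a number.
compound 2, `O=C(C1CC1)N1CCc2nc(C#Cc3ccccc3)sc2C1`: 290 nM in this assay.

Going by the values given here, compound 2 therefore stands with the only number given. The remaining value, that of compound 1, is a limit, at the limit of > 10000 nM in this assay, at which 1 of the 2 values shown sits. Compound 3, `O=C(CC1CCOCC1)N1CCc2nc(C#Cc3ccccc3)sc2C1`, differs from compound 2 in a single place: (oxan-4-yl)methyl in place of cyclopropyl on a carbonyl carbon. Among the compounds with values here, no step between two measured compounds exists to gauge such a change, so the expected step of a 2.1-fold higher number from compound 2 to compound 3 (0.32 log units; beyond the scatter) is a modest loss, only just beyond the usual scatter. Compound 3 is accordingly expected to give about 600 nM, within a range from 150 nM to 2500 nM.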

Compound 3, half-maximal inhibitory concentration: > 10000 nM
Compound 3: no number, only a limit; the forecaster's own chance of this, stated with the estimate: 10%; middle value at least 16-fold (1.22 log units) from the limit.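

In this assay the change on the carbonyl carbon from cyclopropyl to (oxan-4-yl)methyl gives an at least 34-fold higher number from compound 2 to compound 3 (1.53 log units; beyond the scatter) and so shows that this place does not accept every larger group. Going by these compounds alone, it is the first step measured at this place, and it is large. On these data alone, the result for compound 3 is a limit of the assay and not a number, so the true size of the loss stays unknown: the limit of > 10000 nM in this assay, at which 2 of the 3 values shown sit.

Open, as far as these compounds go, is whether the loss goes with the ring oxygen or with the added atoms. A cyclohexylmethyl group on the same carbonyl carbon would separate the two.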